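The source may hold more compounds than are shown below. What is called first, only, known or untested is meant among the compounds shown, and "the series" means these compounds.

- Compound 1 `COc1cccc(-c2cc([N+](=O)[O-])cc3cc(C(O)(c4ccc(C#N)cc4)c4cncn4C)oc23)c1`: 38.8 nM
- Compound 2 `Cn1cncc1C(O)(c1ccc(C#N)cc1)c1cc2cc([N+](=O)[O-])cc(-c3ccc(C#N)cc3)c2o1`: 32.6 nM

In a functional assay on QG-56 cells (Homo sapiens) for antiproliferative activity (on this read-out higher numbers stand for weaker inhibition and lower numbers for stronger inhibition), compound 1 gives 38.8 nM, level with compound 2 within the scatter. Compound 3 `COc1cccc(-c2cc(CO)cc3cc(C(O)(c4ccc(C#N)cc4)c4cncn4C)oc23)c1` has hydroxymethyl in place of nitro on an aromatic carbon of the core of compound 1 (hydroxymethyl in place of nitro on an aromatic carbon). Going by the values given here, the only measured step, a 1.2-fold lower number from compound 1 to compound 2 (0.08 log units; within the scatter), replaces the 3-methoxyphenyl group and leaves nitro untouched. It therefore says nothing direct about this swap, and the data give no firm direction. No shift beyond the scatter is expected, though with wide uncertainty. The expected step is a 1.3-fold higher number from compound 1 to compound 3 (0.11 log units; within the scatter). For compound 3 the estimated value is 50 nM, within an expected range of 12 nM to 200 nM.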

Compound 3, half-maximal inhibitory concentration: 16.8 nM
The estimate for compound 3 lay 3.0-fold (0.47 log units) above the measured number, within the range that was stated.
By their numbers in this assay, from the lowest: compounds 3, 2 and 1 (each within the scatter of the next, the first and the last beyond it).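

In this assay, putting hydroxymethyl in place of nitro gives a 2.3-fold lower number from compound 1 to compound 3 (0.36 log units; beyond the scatter) and so moves the number modestly beyond the scatter. This position therefore responds to a change, whereas the earlier swap of 3-methoxyphenyl for 4-cyanophenyl stayed within the scatter, and nitro is not required for activity in this pair. No measurement here explains the shift.

As far as these compounds go, whether other groups at this position do as well stays open: an amine, a carboxylic acid or a longer chain could test this. From the compounds shown here alone, it is also open whether the same swap holds with 4-cyanophenyl in place of 3-methoxyphenyl.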